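From Fluoro to Methyl on the Phenyl Ring

A few compounds are considered here, and "the series" means these few. Any claim that something is new, unique, unknown or untested is made for them only; others in the source may bear on it.

Measured in a functional assay on PC-3 cells (Homo sapiens) for cytotoxicity, read by MTT assay, with a stated time of 72 h; a higher number here means a weaker inhibitor, a lower number a stronger inhibitor:
Compound 1, `CC1=C(/C=C/C(=O)/C=C/c2ccccc2)C(C)(C)CCC1O`, gives 15500 nM.
Compound 2, `CC1=C(/C=C/C(=O)/C=C/c2cccc(F)c2)C(C)(C)CCC1O`, gives 16000 nM.

Compound 2 carries the nominally higher of the two numbers, but the step of a 1.0-fold higher number from compound 1 to compound 2 (0.01 log units; within the scatter) lies within the scatter, so compound 1 and compound 2 are not separated in this assay. Compound 3, `CC1=C(/C=C/C(=O)/C=C/c2cccc(C)c2)C(C)(C)CCC1O`, differs from compound 2 by methyl in place of fluoro on an aromatic carbon of a six-membered aromatic ring of carbon only, meta to a large group. Going by the values given here, the only measured step that bears on this carbon is a 1.0-fold higher number from compound 1 to compound 2 (0.01 log units; within the scatter), which showed that adding fluoro there left the number unchanged. Among the compounds with values here, no measured step shows methyl at this carbon. The swap is therefore expected to give a small step, a 1.1-fold lower number from compound 2 to compound 3 (0.06 log units; within the scatter), with no direction beyond the scatter in this assay. Compound 3 is estimated at 14000 nM, with a range from 6000 nM to 35000 nM.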

Compound 3, half-maximal inhibitory concentration: 6200 nM
Beside the measured number, compound 3's estimate is 2.3-fold (0.35 log units) above it; the measured number falls inside the stated range.
By their numbers in this assay, from the lowest: compound 3; then compounds 1 and 2 (each within the scatter of the next).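

In this assay, this carbon of the phenyl ring turns out to be able to move the number: the swap of fluoro for methyl gives a 2.6-fold lower number from compound 2 to compound 3 (0.41 log units; beyond the scatter), and methyl in place of hydrogen gives a 2.5-fold lower number from compound 1 to compound 3 (0.40 log units; beyond the scatter), so both comparisons point the same way. Both steps are modest but lie beyond the scatter, whereas fluoro at the same carbon had not separated from hydrogen, so here methyl and fluoro do not behave alike. Nothing shown accounts for this difference between methyl and fluoro.

The compounds shown leave open whether the lower number is particular to methyl or also holds for a longer chain such as ethyl, or for a methoxy group, at this carbon. They also leave open whether methyl on another carbon of the ring would give a similar step.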